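The compounds below may be only part of what the source reports. "The series", "measured", "known", "first", "only" and "open" are said of these compounds alone.

Three compounds have so far been measured in a functional assay on A549 cells (Homo sapiens) for inhibition, read by CCK-8 assay, with a stated time of 72 h, tested at 10 uM; a lower number here means less inhibition of growth, a higher number more inhibition of growth at the concentration tested:

Compound 1 `CN(C)C(=O)c1cc2cnc(Nc3ccc(NC(=O)C4(C(=O)Nc5ccc(Cl)c(C(F)(F)F)c5)CC4)cc3)nc2n1C1CCCC1`: 88.1%
Compound 2 `COc1cccc(NC(=O)C2(C(=O)Nc3ccc(Nc4ncc5cc(C(=O)N(C)C)n(C6CCCC6)c5n4)cc3)CC2)c1`: 96%
Compound 3 `CN(C)C(=O)c1cc2cnc(Nc3ccc(NC(=O)C4(C(=O)Nc5ccc(C(F)(F)F)cc5)CC4)cc3)nc2n1C1CCCC1`: 87.9%

All three share the same core and differ only in the aryl group on one amide-type nitrogen. Compound 1 sits between the other two numbers, but neither neighbour is truly apart from it: the step of a number 0.2 percentage points lower from compound 1 to compound 3 (within the scatter) and the step of a number 7.9 percentage points higher from compound 1 to compound 2 (within the scatter) both fall inside the usual scatter, as does the step of a number 8.1 percentage points lower from compound 2 to compound 3 (within the scatter).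

Compound 4 `CN(C)C(=O)c1cc2cnc(Nc3ccc(NC(=O)C4(C(=O)Nc5ccc(F)cc5)CC4)cc3)nc2n1C1CCCC1` has not yet been measured. Its difference from compound 1 is 4-fluorophenyl in place of 4-chloro-3-(trifluoromethyl)phenyl on an amide-type nitrogen.

For the measured compounds named here, two measured steps bear on this change. Both also replace the 4-chloro-3-(trifluoromethyl)phenyl group of compound 1 on the same amide-type nitrogen: the move to 4-(trifluoromethyl)phenyl, a number 0.2 percentage points lower from compound 1 to compound 3 (within the scatter), and the move to 3-methoxyphenyl, a number 7.9 percentage points higher from compound 1 to compound 2 (within the scatter). Neither exceeded the scatter, so a third aryl variant at this position is not expected to move this assay beyond the scatter either, in any direction.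

Compound 4 is therefore estimated to give 87%, with a likely range from 76% to 96%. The estimated step here is a number 1.1 percentage points lower from compound 1 to compound 4 (within the scatter).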

Compound 4, percent growth inhibition at one concentration: 102%
Estimate against measurement, compound 4: 15 percentage points below; the whole stated range lies below it.
By their numbers in this assay, from the lowest: compounds 3, 1, 2 and 4 (each within the scatter of the next, the first and the last beyond it).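

In this assay, for the compounds shown here, the aryl group on this amide-type nitrogen can make a measurable difference: a number 13.9 percentage points higher from compound 1 to compound 4 (beyond the scatter) and a number 14.1 percentage points higher from compound 3 to compound 4 (beyond the scatter) are the first steps at this position to pass beyond the scatter, though both are modest. The second step is the narrower comparison, since only one substituent on the aromatic ring changes, with fluoro in place of trifluoromethyl, whereas the first also removes the chlorine; the change to 4-fluorophenyl is therefore not tied to losing the chlorine alone, yet a number 6 percentage points higher from compound 2 to compound 4 (within the scatter) stays within the scatter, so this assay does not separate the 4-fluorophenyl and 3-methoxyphenyl compounds. No measurement is available that gives a reason for these steps.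

The compounds shown carry only substituted phenyl rings on this nitrogen, so it remains open how an unsubstituted phenyl, a saturated ring such as cyclohexyl, or a phenyl bearing an amine or a carboxylic acid would behave. On these data alone, with readings at a single concentration on one cell line, it also remains open whether these compounds would still differ at lower doses.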